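Sulfonamide ring swap at the end of compound 2

A few compounds are considered here, and "the series" means these few. Any claim that something is new, unique, unknown or untested is made for them only; others in the source may bear on it.

The shared core is that of compound 1 `Cc1c(CC(=O)O)c2ccsc2n1S(=O)(=O)c1ccccc1`, which in an assay on HEK293 cells for displacement of a labelled ligand from prostaglandin D2 receptor 2 (Homo sapiens) (on this read-out higher numbers stand for weaker inhibition and lower numbers for stronger inhibition), gives 2750 nM. Among the measured compounds shown here, compound 2 `Cc1c(CC(=O)O)c2ccsc2n1S(=O)(=O)c1ccc(S(=O)(=O)N2CCOCC2)cc1` carries a (morpholin-4-yl)sulfonyl group on an aromatic carbon and in this assay gives 230 nM; the step of a 12-fold lower number from compound 1 to compound 2 (1.08 log units; beyond the scatter) is the only measured step so far, and on it compound 2 holds the lowest of the two numbers, with compound 1 as its nearest neighbour.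

Compound 3 `Cc1c(CC(=O)O)c2ccsc2n1S(=O)(=O)c1ccc(S(=O)(=O)N2CCCC2)cc1` differs from compound 2 by pyrrolidin-1-yl in place of morpholin-4-yl on a sulfonyl sulfur. For the measured compounds named here, no measured step touches this part of the molecule directly. Going by the values given here, the one step on hand, a 12-fold lower number from compound 1 to compound 2 (1.08 log units; beyond the scatter), shows only that the whole sulfonyl substituent on the aromatic carbon carries weight in this assay; it says nothing about exchanging one non-aromatic ring for another within that substituent. The expectation is therefore a step no larger than the usual scatter in this assay, in either direction, written as a 1.1-fold higher number from compound 2 to compound 3 (0.04 log units; within the scatter). For compound 3 the expected value in this assay is 250 nM, with a range from 100 nM to 650 nM.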

Compound 3, half-maximal inhibitory concentration: 390 nM
Compound 3: the middle estimate sits 1.6-fold (0.19 log units) below what was measured; measured number inside the range.
By their numbers in this assay, from the lowest: compounds 2 and 3 (each within the scatter of the next); then compound 1.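

In this assay, replacing the six-membered non-aromatic ring with 2 hetero atoms by a five-membered non-aromatic ring with 1 hetero atom gives a 1.7-fold higher number from compound 2 to compound 3 (0.23 log units; within the scatter), so the two rings on the sulfonyl sulfur cannot be told apart on this read-out. The substituent also keeps a step beyond the scatter without morpholin-4-yl, with a 7.1-fold lower number from compound 1 to compound 3 (0.85 log units; beyond the scatter), which shows that the separation from compound 1 does not depend on that one ring. No accompanying data bear on this result or offer a cause for it.

The shown set covers only these two non-aromatic rings on the sulfonyl sulfur, so it remains open whether piperidin-1-yl, a piperazine ring with a free ring amine, or an open-chain dimethylamino group would read the same way in this assay. From the compounds shown here alone, it is also open whether the sulfonyl link itself matters, as a carbonyl joining the same rings to the aromatic carbon would show, and whether a carboxylic acid at the end of the substituent would shift the number beyond the scatter.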